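Working notes on compounds 1 to 3

The source may hold more compounds than are shown below. What is called first, only, known or untested is meant among the compounds shown, and "the series" means these compounds.

Measured so far in a functional assay on BCG823 cells (Homo sapiens) for inhibition, read by MTT assay, with a stated time of 72 h; on this read-out lower numbers stand for stronger inhibition and higher numbers for weaker inhibition:
compound 1 `CN(C(=O)NC(=O)c1ccc([N+](=O)[O-])cc1)c1nc(C(F)(F)F)c(C(=O)N/N=C/c2cccc(C(F)(F)F)c2)s1`: 1.67 ug/mL
compound 2 `CN(C(=O)NC(=O)c1ccc([N+](=O)[O-])cc1)c1nc(C(F)(F)F)c(C(=O)N/N=C/c2ccc([N+](=O)[O-])cc2)s1`: 7.45 ug/mL

Compound 1 stands at the lowest of the two numbers in this assay; compound 2 is the nearest, with a 4.5-fold higher number from compound 1 to compound 2 (0.65 log units; beyond the scatter). Compound 3 `CN(C(=O)NC(=O)c1ccc(Cl)cc1Cl)c1nc(C(F)(F)F)c(C(=O)N/N=C/c2cccc(C(F)(F)F)c2)s1` differs from compound 1 by 2,4-dichlorophenyl in place of 4-nitrophenyl on a carbonyl carbon. Within the data shown here, the one measured step, a 4.5-fold higher number from compound 1 to compound 2 (0.65 log units; beyond the scatter), lies on the carbon with a double bond to nitrogen and so does not bear on this change; no step on the carbonyl carbon is measured. Without a step that bears on it, compound 3 is expected to lie near compound 1, with a 1.3-fold higher number from compound 1 to compound 3 (0.12 log units; within the scatter) within the scatter. Compound 3 is estimated at 2.2 ug/mL, range 0.7 ug/mL to 7 ug/mL.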

Compound 3, half-maximal inhibitory concentration: 6.11 ug/mL
Beside the measured number, compound 3's estimate is 2.8-fold (0.44 log units) below it, within the range that was stated.
By their numbers in this assay, from the lowest: compound 1; then compounds 3 and 2 (each within the scatter of the next).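

In this assay, among these compounds, the group on the carbonyl carbon is not silent: 2,4-dichlorophenyl in place of 4-nitrophenyl gives a 3.7-fold higher number from compound 1 to compound 3 (0.56 log units; beyond the scatter) as the first measured step at this position. Both places varied so far now carry a step beyond the scatter, with compound 1 at the lower number in each. No measurement at hand bears on the reason for this step.

Open, going by these compounds, is whether the step follows the loss of the nitro group or the entry of the two chlorines. Also open, on these data alone, is how a phenyl bearing a single chlorine, an amine or a carboxylic acid would read at this position.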